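From hydroxy to acetoxy on compound 3

A few compounds are considered here, and "the series" means these few. Any claim that something is new, unique, unknown or untested is made for them only; others in the source may bear on it.

Compound 1 `C=CCOc1cc(C2=C(c3cc(OC)c(OC)c(OC)c3)C(=O)C(O)C2)ccc1OC` gives > 100 ug/mL, a limit
Compound 2 `COc1ccc(OC)c(C2=C(c3cc(OC)c(OC)c(OC)c3)C(=O)CC2O[SiH2]C(C)(C)C)c1` gives > 100 ug/mL, a limit
Compound 3 `COc1cc(C2=C(c3cc(C)c(OC)c(C)c3)C(O)CC2=O)cc(OC)c1OC` gives > 100 ug/mL, a limit

These results come from an ADME assay on MIA PaCa-2 cells (Homo sapiens) for cytotoxicity, read by MTT assay, with a stated time of 72 h; on this read-out lower numbers stand for stronger inhibition and higher numbers for weaker inhibition. The set offers no actual number to work with, only (the limit of > 100 ug/mL in this assay, at which 3 of the 3 values shown sit). Compound 3 therefore stands at the limit with the others. Its entry > 100 ug/mL is a limit and not a measured number.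

The next compound to be tested is compound 4 `COc1cc(C2=C(c3cc(C)c(OC)c(C)c3)C(OC(C)=O)CC2=O)cc(OC)c1OC`. It keeps the rest of compound 3 and changes in one place, hydroxy to acetoxy: acetyl in place of hydrogen on an oxygen on a saturated carbon. In plain terms, an acetyl takes the place of a hydrogen on an oxygen on a saturated carbon.

Going by the values given here, no measured pair in this set shows what such a change does, so the expectation in this assay is a cautious one. With nothing pointing in either direction, no step beyond the usual scatter is expected. The expected step is a number no higher from compound 3 to compound 4 (the limit leaves the size open). Another report of only a limit is quite likely for this compound. For compound 4 the estimated value is 100 ug/mL, with an expected range from 40 ug/mL to 250 ug/mL.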

Compound 4, half-maximal inhibitory concentration: > 100 ug/mL
Compound 4: a limit, no number; the forecaster's own chance of this, stated with the estimate: 65%; the middle value lies on the limit itself.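

In this assay compound 4 gives > 100 ug/mL, which is a limit and not a number. Compound 3 also stands at a limit, so no step can be read between compound 3 and compound 4. The compounds shown leave open what the change from hydroxy to acetoxy does to the read-out, and every result sits at the same limit: the limit of > 100 ug/mL in this assay, at which 4 of the 4 values shown sit.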